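This account rests on a few compounds, and the source may have more. Where it says the series, first, only, none or still open, it means among the compounds named here.

Measured so far:
Compound 1 `CCOc1cccc(/C=N/c2c(C)n(C)n(-c3ccccc3)c2=O)c1` — 295000000 nM
Compound 2 `Cc1c(/N=C/c2ccccc2)c(=O)n(-c2ccccc2)n1C` — 851000000 nM

Compound 1 and compound 2 were tested in a functional assay on HT-29 cells (Homo sapiens) for cytotoxicity, read by MTT assay, with a stated time of 72 h; a lower number here means a stronger inhibitor, a higher number a weaker inhibitor. For the measured compounds named here, of the two numbers, compound 1 has the lower one, and the only neighbour is compound 2, which lies beyond the scatter from it: a 2.9-fold higher number from compound 1 to compound 2 (0.46 log units; beyond the scatter). Going by the values given here, that step, hydrogen in place of ethoxy on an aromatic carbon, is the single measured change on record and it counts as modest.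

Compound 3 `Cc1c(/N=C/c2cccc(Cl)c2)c(=O)n(-c2ccccc2)n1C` has not yet been tested in this assay. Against compound 1 the change is chloro in place of ethoxy on an aromatic carbon. The step from compound 1 to compound 2 bears on it in part, since it too removes the ethoxy; what it does not tell is what the entering chloro adds back. The account therefore expects a step of the same direction but smaller than a 2.9-fold higher number from compound 1 to compound 2 (0.46 log units; beyond the scatter), or possibly none beyond the scatter. For compound 3 the expected step is a 1.5-fold higher number from compound 1 to compound 3 (0.18 log units; within the scatter). The estimate for compound 3 in this assay is 450000000 nM, with a range from 200000000 nM to 1000000000 nM.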

Compound 3, half-maximal inhibitory concentration: 269000000 nM
Estimate against measurement, compound 3: 1.7-fold (0.22 log units) above, and the stated range covers the measured number.
By their numbers in this assay, from the lowest: compounds 3 and 1 (each within the scatter of the next); then compound 2.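

In this assay, the place on the aromatic ring meta to a large group proves not to depend on the ethoxy as such: chloro in place of ethoxy gives a 1.1-fold lower number from compound 1 to compound 3 (0.04 log units; within the scatter), so a single chlorine atom matches a group of 3 heavy atoms, one of them oxygen, and the step is within the scatter. Chloro in place of hydrogen gives a 3.2-fold lower number from compound 2 to compound 3 (0.50 log units; beyond the scatter), a modest step comparable in size to the one seen earlier between hydrogen and ethoxy, so among these three compounds it is compound 2, with hydrogen at this place, that stands apart, while the two substituted compounds sit together. No measurement at hand explains why two such different groups give matching numbers.

From the compounds shown here alone, whether this agreement holds for other groups at the same place remains open, for instance an amine, a carboxylic acid or a longer chain such as butoxy. Also open, going by these compounds, is whether any group here can move the number further from that of compound 2 than chloro and ethoxy do, since both of these leave the series within a narrow span.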